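From 4-nitrophenyl to 2,4-difluorophenyl at the assay limit

The compounds below may be only part of what the source reports. "The series", "measured", "known", "first", "only" and "open" are said of these compounds alone.

Measured in a functional assay on Jurkat cells (Homo sapiens); on this read-out lower numbers stand for stronger inhibition and higher numbers for weaker inhibition:
- compound 1 (`CC(C)[C@H](NC(=O)COc1cccc2ccccc12)C(=O)N[C@@H](CC(=O)O)C(=O)COc1cccc2ccccc12`): > 100000 nM (a limit)
- compound 2 (`CC(C)[C@H](NC(=O)COc1cccc2ccccc12)C(=O)N[C@@H](CC(=O)O)C(=O)COc1ccc([N+](=O)[O-])cc1`): > 100000 nM (a limit)

Among the measured compounds shown here, compound 2 gives > 100000 nM as its only reading, and this is a limit of the assay and not a number. It has no measured neighbour with a readable value, for both compounds share the same reading (the limit of > 100000 nM in this assay, at which 2 of the 2 values shown sit). Compound 3 (`CC(C)[C@H](NC(=O)COc1cccc2ccccc12)C(=O)N[C@@H](CC(=O)O)C(=O)COc1ccc(F)cc1F`) differs from compound 2 in one place, on an oxygen on a saturated carbon, where 2,4-difluorophenyl stands in place of 4-nitrophenyl (2,4-difluorophenyl in place of 4-nitrophenyl on an oxygen on a saturated carbon).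

For the measured compounds named here, one measured step touches the same place (a step that the two limits leave unreadable from compound 1 to compound 2), and it offers neither a size nor a direction. Going by the values given here, the data therefore fix no size of step in this assay for this change, and the expectation is simply that the reading stays near the limit, with a readable value still possible. The expected step is a number no higher from compound 2 to compound 3 (the limit leaves the size open) and remains a rough estimate. The estimate for compound 3 is an expected 100000 nM (range 15000 nM to 300000 nM).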

Compound 3, half-maximal inhibitory concentration: 33200 nM
For compound 3 the middle estimate is 3.0-fold (0.48 log units) above the measured one, and the stated range covers the measured number.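

Among the compounds shown here, compound 3 is the first compound here whose aryl group on this oxygen gives a readable number, so this place can move the reading in this assay, something the earlier pair could not show. The replacement of 4-nitrophenyl by 2,4-difluorophenyl gives an at least 3.0-fold lower number from compound 2 to compound 3 (0.47 log units; beyond the scatter), and the replacement of naphthalen-1-yl by the same group gives an at least 3.0-fold lower number from compound 1 to compound 3 (0.47 log units; beyond the scatter). Both sizes are lower bounds only, and the two starting compounds cannot be ordered against each other, since each reading is capped: the limit of > 100000 nM in this assay, at which 2 of the 3 values shown sit.

What the compounds leave open is how large either step really is, and which feature of 2,4-difluorophenyl carries the change, a question that a plain phenyl, a 4-fluorophenyl or a 2-fluorophenyl group on the same oxygen would begin to separate. Also open, from the compounds shown here alone, is whether a group such as 2,3,5,6-tetrafluorophenyl would lower the number further in this assay, or whether the reading for compound 3 of 33200 nM is close to what this place can give on the shared core.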